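The source may hold more compounds than are shown below. What is called first, only, known or untested is meant among the compounds shown, and "the series" means these compounds.

Half-lives in an ADME assay on microsomes from liver (Mus musculus) for metabolic stability; a higher number here means that the compound lasts longer, a lower number that the compound disappears faster:
- compound 1 `NS(=O)(=O)CC(=O)NCCSc1nonc1/C(=N/O)Nc1ccc(F)c(C(F)F)c1`: 1.07 h
- compound 2 `CC(C)(O)CC(=O)NCCSc1nonc1/C(=N/O)Nc1ccc(F)c(C(F)F)c1`: 0.175 h

Compound 2 holds the lower of the two numbers in this assay. The next compound, compound 3 `CS(=O)(=O)CC(=O)NCCSc1nonc1/C(=N/O)Nc1ccc(F)c(C(F)F)c1`, differs from it as follows: methylsulfonyl in place of 1-hydroxy-1-methylethyl on a saturated chain carbon bound to a carbonyl carbon. Among the measured compounds shown here, one measured step bears on this change: a 6.1-fold lower number from compound 1 to compound 2 (0.79 log units; beyond the scatter), beyond the scatter, with 1-hydroxy-1-methylethyl replacing sulfamoyl at the same place. Methylsulfonyl resembles the sulfamoyl of compound 1 (1.07 h), so a rise of somewhat smaller size is expected. The expected change is a 4.0-fold higher number from compound 2 to compound 3 (0.60 log units; beyond the scatter). Compound 3 is estimated at 0.7 h, with an expected range of 0.25 h to 2 h.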

Compound 3, half-life: 0.765 h
The estimate for compound 3 lay 1.1-fold (0.04 log units) below the measured number; low and high end bracket the measured number.
By their numbers in this assay, from the lowest: compound 2; then compounds 3 and 1 (each within the scatter of the next).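

In this assay, methylsulfonyl in place of 1-hydroxy-1-methylethyl gives a 4.4-fold higher number from compound 2 to compound 3 (0.64 log units; beyond the scatter), so the low number of compound 2 now stands against two sulfonyl-bearing groups at this place, not one. Methyl in place of amino on the sulfonyl sulfur gives a 1.4-fold lower number from compound 1 to compound 3 (0.15 log units; within the scatter), and this swap does not separate compound 1 from compound 3. Nothing available explains the gap to compound 2.

Open, going by these compounds, is whether a larger group on the sulfonyl sulfur, such as ethyl or phenyl, holds the number, and where a carboxylic acid or an amine at this place would fall. Also open, on these data alone, is whether the gap to 1-hydroxy-1-methylethyl persists on a different core.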